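The source may hold more compounds than are shown below. What is called first, only, known or untested is meant among the compounds shown, and "the series" means these compounds.

Measured in an ADME assay on microsomes from liver (Rattus norvegicus) for metabolic stability; on this read-out higher numbers stand for a longer-lived compound and lower numbers for a shorter-lived compound:
- compound 1 `CC(C)C(Cc1ncc[nH]1)c1ccc(-c2ccc3cccc(F)c3c2)[nH]c1=O`: < 0.0667 h (a limit of the assay, not a number)
- compound 2 `CC(C)C(Nc1nnc[nH]1)c1ccc(-c2ccc3cccc(F)c3c2)[nH]c1=O`: 1.29 h
- compound 3 `CC(C)C(c1nnc[nH]1)c1ccc(-c2ccc3cccc(F)c3c2)[nH]c1=O`: 0.552 h

Compound 3 holds the lower of the two true numbers, the gap being a 2.3-fold lower number from compound 2 to compound 3 (0.37 log units; beyond the scatter). Compound 4 `CC(C)C(Cc1nnn[nH]1)c1ccc(-c2ccc3cccc(F)c3c2)[nH]c1=O` carries (1H-tetrazol-5-yl)methyl in place of 4H-1,2,4-triazol-3-yl on a saturated chain carbon bound to an aromatic carbon and a saturated chain carbon.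

Within the data shown here, the closest precedent is compound 1, which also has a ring on a methyl link. Removing that link and changing the ring gave an at least 8.2-fold higher number from compound 1 to compound 3 (0.91 log units; beyond the scatter), and an at least 19-fold higher number from compound 1 to compound 2 (1.28 log units; beyond the scatter) also starts from it. Compound 4 shares the link but not the ring of compound 1, so only part of that step is expected in reverse. The expected change in this assay is a 2.2-fold lower number from compound 3 to compound 4 (0.34 log units; beyond the scatter), a modest step downward. For compound 4 the estimated value is 0.25 h, with an expected range of 0.07 h to 1 h.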

Compound 4, half-life: 2.08 h
Beside the measured number, compound 4's estimate is 8.3-fold (0.92 log units) below it, outside the stated range (above it).
By their numbers in this assay, from the lowest: compound 3; then compounds 2 and 4 (each within the scatter of the next). At a limit, below all of these: compound 1.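

In this assay, with 1H-tetrazol-5-yl in place of 1H-imidazol-2-yl, an at least 31-fold higher number from compound 1 to compound 4 (1.49 log units; beyond the scatter) shows that a methyl link on this saturated chain carbon does not by itself give a low number. Replacing 4H-1,2,4-triazol-3-yl gives a 3.8-fold higher number from compound 3 to compound 4 (0.58 log units; beyond the scatter), while a 1.6-fold higher number from compound 2 to compound 4 (0.21 log units; within the scatter) leaves those two compounds unseparated. Compound 1, the start of the first step, stands at a limit, not a number: the limit of < 0.0667 h in this assay, at which 1 of the 4 values shown sits.

The step from compound 3 changes ring and link together, and (4H-1,2,4-triazol-3-yl)methyl would part the two. As far as these compounds go, how a carboxylic acid on the same methyl link would read stays open.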